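This account rests on a few compounds, and the source may have more. Where it says the series, first, only, none or still open, it means among the compounds named here.

Measured so far:
- compound 1, `c1ccc(-c2nc3cccnc3o2)cc1`: 55%
- compound 2, `Clc1ccccc1-c1nc2ncccc2o1`: 38%
- compound 3, `Clc1cccc(-c2nc3cccnc3o2)c1`: 8%

All three values come from a functional assay on the whole organism for inhibition, with Rattus norvegicus as the target, at a dose of 30 mg/kg; a higher number here means more inhibition at the dose given (going by the name of the read-out), a lower number less inhibition. Compound 1 gives the highest number, compound 3 the lowest, and compound 2 stands between them, beyond the scatter from each. The difference between the cores of compound 1 and compound 2 is not broken down here.

Within the data shown here, the one counted change, from compound 1 to compound 3, is chloro in place of hydrogen on an aromatic carbon; it brought a number 47 percentage points lower from compound 1 to compound 3 (beyond the scatter), a large drop. The same kind of change is made from compound 2 to the unmeasured compound 4, `Clc1cccc(Cl)c1-c1nc2ncccc2o1`: chloro in place of hydrogen on an aromatic carbon. The surroundings differ: in compound 3 the chloro sits meta to a group of 9 heavy atoms, whereas in compound 4 it sits ortho to a group of 9 heavy atoms and meta to a chloro group. Among the measured compounds shown here, only one instance of the change has been measured, so the expectation rests on that single step.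

Going by the drop seen in a number 47 percentage points lower from compound 1 to compound 3 (beyond the scatter), compound 4 is expected to fall from compound 2 by about a number 26 percentage points lower from compound 2 to compound 4 (beyond the scatter) in this assay. Compound 4 is estimated at 12%, most likely between 0% and 35%.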

Compound 4, a percentage reported as inhibition, in the whole organism at one dose (the size of the read-out at that dose, not a potency): 14%
Estimate against measurement, compound 4: 2 percentage points below; measured number inside the range.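

In this assay, chloro in place of hydrogen on an aromatic carbon again lowers the number, giving a number 24 percentage points lower from compound 2 to compound 4 (beyond the scatter). The direction of the change carries over from one core to the other, but its size does not: the same change on two cores in this assay, a number 47 percentage points lower (beyond the scatter) from compound 1 to compound 3 and a number 24 percentage points lower (beyond the scatter) from compound 2 to compound 4, 23 percentage points apart, beyond the scatter of two such steps This shows that the size of the drop cannot be assumed constant in this series; it does not show what sets the size, as the two steps differ both in the core and in the surroundings of the chloro, which in compound 4 sits ortho to a group of 9 heavy atoms and meta to a chloro group.

The compounds shown carry only hydrogen or chloro on the six-membered aromatic ring of carbon only, so what a methoxy group, an amine or a carboxylic acid would do there in this assay stays open. No two compounds shown differ in the core alone, so the contribution of the core by itself also stays open.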